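Methoxy to Hydroxy on Two Related Cores: Estimating Compound 4

A few compounds are considered here, and "the series" means these few. Any claim that something is new, unique, unknown or untested is made for them only; others in the source may bear on it.

The measured compounds in a functional assay on COLO 205 cells (Homo sapiens) for inhibition, read by sulforhodamine B assay, with a stated time of 48 h; on this read-out lower numbers stand for stronger inhibition of growth and higher numbers for weaker inhibition of growth:

Compound 1, `COc1cc(-c2nn(-c3cccc(NC(=O)Nc4cc(C(F)(F)F)cc(C(F)(F)F)c4)c3)cc2-c2ccncc2)ccc1Cl`, gives 1570 nM.
Compound 2, `O=C(Nc1cccc(-n2cc(-c3ccncc3)c(-c3ccc(Cl)c(O)c3)n2)c1)Nc1cc(C(F)(F)F)cc(C(F)(F)F)c1`, gives 1580 nM.
Compound 3, `COc1cc(-c2nn(-c3cccc(NC(=O)Nc4ccc(Cl)c(C(F)(F)F)c4)c3)cc2-c2ccncc2)ccc1Cl`, gives 1540 nM.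

Compound 1 and compound 2 share a core and differ in one place: hydrogen in place of methyl on an oxygen on an aromatic ring. In this assay this change made a 1.0-fold higher number from compound 1 to compound 2 (0.00 log units; within the scatter), so the two values lie within the scatter of each other and no order between them can be read.

Compound 3 carries a different urea end than compound 1; the difference between the two cores is not broken down here. Its value in this assay sits within the scatter of both compound 1 and compound 2, so none of the three can be called stronger or weaker than another.

Compound 4, `O=C(Nc1cccc(-n2cc(-c3ccncc3)c(-c3ccc(Cl)c(O)c3)n2)c1)Nc1ccc(Cl)c(C(F)(F)F)c1`, has not yet been measured. It stands to compound 3 as compound 2 stands to compound 1: hydrogen in place of methyl on an oxygen on an aromatic ring. The place of the change is the same, word for word, in both pairs, so this is the same change seen once more.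

Because a 1.0-fold higher number from compound 1 to compound 2 (0.00 log units; within the scatter) stayed within the scatter, the same change on the core of compound 3 is expected to make a 1.0-fold higher number from compound 3 to compound 4 (0.00 log units; within the scatter) in this assay. On that basis compound 4 is estimated at 1550 nM, with a range from 800 nM to 3000 nM reflecting only the usual scatter of repeated measurements.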

Compound 4, concentration for total growth inhibition: 6750 nM
Compound 4: middle estimate off by 4.4-fold (0.64 log units), on the low side; the measured number lies above the stated range.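

On the core of compound 3, the change from methoxy to hydroxy in this assay gave a 4.4-fold higher number from compound 3 to compound 4 (0.64 log units; beyond the scatter), which here means weaker inhibition of growth, whereas the same change had left the number on the core of compound 1 within the scatter. The two steps therefore do not agree, and the outcome of this change on one core could not be carried over to the other in this series: the same change on two cores in this assay, a 1.0-fold higher number (0.00 log units; within the scatter) from compound 1 to compound 2 and a 4.4-fold higher number (0.64 log units; beyond the scatter) from compound 3 to compound 4, 4.4-fold (0.64 log units) apart, beyond the scatter of two such steps

This shows that, for these two pairs, the size of the step depends on which urea end the compound carries, but it does not show why, and two pairs give no rule for how the change would behave on any further core.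

The compounds shown leave open whether the step seen on the core of compound 3 is tied to that particular urea end or would recur on others. They also leave open how an amine in place of the hydroxy, or an ethyl group in place of the methyl on the same oxygen, would read in this assay on each of the two cores.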